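Swapping the furan arm of compound 2 for a pyrazine

This account rests on a few compounds, and the source may have more. Where it says the series, first, only, none or still open, it means among the compounds named here.

Compound 1 `Cc1ccc(-c2nc3c(N)nc(NCc4cccs4)nc3s2)o1` gives 91 nM in a functional assay on CHO cells for agonist activity at adenosine receptor A2b (Homo sapiens), read by scintillation counting and cAMP accumulation, with a stated time of 150 min, in the presence of a further agent that is not named here; on this read-out higher numbers stand for weaker inhibition and lower numbers for stronger inhibition.
Compound 2 `Nc1nc(NCc2ccco2)nc2sc(-c3ccco3)nc12` gives 82 nM in this assay.
Compound 3 `COc1cccc(CNc2nc(N)c3nc(-c4cccs4)sc3n2)c1` gives 2770 nM in this assay.

Compound 2 has the lowest number of the three; compound 1 sits within the scatter of it, while compound 3 lies well beyond it. Compound 4 `Nc1nc(NCc2cnccn2)nc2sc(-c3ccco3)nc12` differs from compound 2 by one change: pyrazin-2-yl in place of furan-2-yl on a saturated chain carbon bound to a nitrogen on an aromatic ring. Within the data shown here, no measured pair shows this same change, so nothing here tells how the methylene-linked ring matters. Compound 4 is therefore expected to give about 250 nM, with a range from 60 nM to 1000 nM. That estimate means an expected step of a 3.0-fold higher number from compound 2 to compound 4 (0.48 log units; beyond the scatter), a mild weakening that may still fall inside the scatter.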

Compound 4, half-maximal inhibitory concentration: 13.2 nM
Compound 4: the middle estimate sits 19-fold (1.28 log units) above what was measured, and the stated range ends above it.
By their numbers in this assay, from the lowest: compound 4; then compounds 2 and 1 (each within the scatter of the next); then compound 3.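

In this assay, pyrazin-2-yl in place of furan-2-yl on the saturated chain carbon gives a 6.2-fold lower number from compound 2 to compound 4 (0.79 log units; beyond the scatter), a step beyond the scatter towards stronger inhibition. This single pair shows that the position accepts a six-membered aromatic ring with 2 hetero atoms and does better with it than with the five-membered ring. No measurement here explains this gain. On these data alone, it remains open whether pyridin-2-yl, with one ring nitrogen, would give a similar step. As far as these compounds go, it is also open whether a longer chain carrying pyrazin-2-yl would keep it.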